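Aryl ether on the hydroxyethyl arm: series notes

This account rests on a few compounds, and the source may have more. Where it says the series, first, only, none or still open, it means among the compounds named here.

Measured so far in an assay on cells for agonist activity at Bombesin receptor subtype-3 (Mus musculus), read by HTRF and inositol phosphate accumulation, with a stated time of 1 h; on this read-out higher numbers stand for an effect only at larger amounts of compound and lower numbers for an effect already at smaller amounts:
compound 1, `CC(C)(C)Cc1cnc(CCc2ccc(-c3cccc(F)c3C(=O)O)cc2)n1CCC(=O)O`, gives 61 nM
compound 2, `CC(C)(C)Cc1cnc(CCc2ccc(-c3cccc(F)c3C(=O)O)cc2)n1CCO`, gives 2 nM

Compound 2 holds the lowest of the two numbers; the step of a 31-fold lower number from compound 1 to compound 2 (1.48 log units; beyond the scatter) separates it from compound 1. Compound 3, `CC(C)(C)Cc1cnc(CCc2ccc(-c3cccc(F)c3C(=O)O)cc2)n1CCOc1cccc(O)c1`, differs from compound 2 by 3-hydroxyphenyl in place of hydrogen on an oxygen on a saturated carbon. Within the data shown here, no measured step concerns this position; the one known step touches the chain end, not an ether on it. Among the measured compounds shown here, with no precedent, a modest shift is expected, a 3.0-fold higher number from compound 2 to compound 3 (0.48 log units; beyond the scatter), the sign open. Compound 3 is therefore estimated at 6 nM, between 1 nM and 40 nM.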

Compound 3, half-maximal effective concentration: 0.8 nM
Compound 3: the middle estimate sits 7.5-fold (0.88 log units) above what was measured; the whole stated range lies above it.
By their numbers in this assay, from the lowest: compound 3; then compound 2; then compound 1.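

In this assay the oxygen of the hydroxyethyl arm accepts 3-hydroxyphenyl with no loss, the number going down (a 2.5-fold lower number from compound 2 to compound 3 (0.40 log units; beyond the scatter)), so the free hydroxy end seen in compound 2 is not required. Replacing the carboxy arm with the 2-(3-hydroxyphenoxy)ethyl arm gives the widest step in the series (a 76-fold lower number from compound 1 to compound 3 (1.88 log units; beyond the scatter)). Nothing available gives a reason for either step.

Open is whether the hydroxy on the new ring contributes, since a plain phenyl ether and a 3-methoxyphenyl ether lie outside the compounds shown. Going by these compounds, an amine in place of the ether oxygen, or a longer chain leading to it, also remains open.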